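The compounds below may be only part of what the source reports. "The series", "measured", "known", "first", "only" and "open" are said of these compounds alone.

In a functional assay with Oryctolagus cuniculus as the target (on this read-out higher numbers stand for weaker inhibition and lower numbers for stronger inhibition), three compounds that share one core have been measured. Compound 1 `COc1ccc(-c2nc(/N=C(\N)NC3CCCCC3)sc2-c2ccc(OC)cc2)cc1` gives > 1000 nM, which is a limit of the assay and not a number. Compound 2 `COc1ccc(-c2nc(CN(C)C)sc2-c2ccc(OC)cc2)cc1` gives 96 nM. Going by these compounds, compound 3 `COc1ccc(-c2nc(C(=O)N(C)C)sc2-c2ccc(OC)cc2)cc1` gives < 100 nM, also a limit and not a number, so its exact standing remains open. Compound 4 `COc1ccc(-c2nc(C(=O)N3CCOCC3)sc2-c2ccc(OC)cc2)cc1` carries morpholin-4-yl in place of dimethylamino on a carbonyl carbon.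

The measured steps bear on this only loosely. Both an at least 10-fold lower number from compound 1 to compound 2 (1.01 log units; beyond the scatter) and an at least 10-fold lower number from compound 1 to compound 3 (1.00 log units; beyond the scatter) lie beyond the scatter, but each replaces a whole group on an aromatic carbon. The remaining step, a step that the limit leaves unreadable from compound 2 to compound 3, gives no size to work from. For the measured compounds named here, no measured step changes the group on the carbonyl carbon, so this assay is expected to show no step clearly beyond the scatter, and no direction can be favoured. The expected step is a step that the limit leaves unreadable from compound 3 to compound 4. For compound 4 the estimated value is 60 nM, with an expected range from 10 nM to 300 nM.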

Compound 4, half-maximal inhibitory concentration: < 10 nM
Compound 4 gave a limit, no number (the forecaster's own chance of this, stated with the estimate: 40%); middle value at least 6.0-fold (0.77 log units) away from the limit.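

In this assay compound 4 gives < 10 nM, a limit of the assay and not a number, so morpholin-4-yl on the carbonyl carbon, the only change at this place among the compounds shown, still leaves inhibition strong. The direct step from dimethylamino to morpholin-4-yl cannot be read, since compound 3 and compound 4 both stand at limits. The comparisons with the other compounds can be read, and they show an at least 9.6-fold lower number from compound 2 to compound 4 (0.98 log units; beyond the scatter) and an at least 100-fold lower number from compound 1 to compound 4 (2.00 log units; beyond the scatter), with the amide carrying the ring now reaching further from compound 2 than the limit of compound 3 could show.

Going by these compounds, whether compound 4 truly differs from compound 3 stays open, as neither has a number. Also open, on these data alone, is whether the ring alone or its oxygen matters, a question that a piperidin-1-yl on the carbonyl carbon would address.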